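Shared-core series: chloro to methoxy, chain homologation

The source may report more compounds than this note shows. Statements on the series, on what has been measured and on what is new or still open speak of the compounds shown alone.

Measured compounds:
compound 1 `CCCCC(CCO)n1cnc2c(Cl)ncnc21`: > 50000 nM
compound 2 `CCCCC(CCO)n1cnc2c(OC)ncnc21`: > 50000 nM
compound 3 `CCCCCC(CCO)n1cnc2c(Cl)ncnc21`: > 50000 nM

For the measured compounds named here, in a functional assay on SW480 cells (Homo sapiens) for antiproliferative activity, read by MTT assay, with a stated time of 48 h (a higher number here means a weaker inhibitor, a lower number a stronger inhibitor), every value so far is a limit of the assay, not a number (the limit of > 50000 nM in this assay, at which 3 of the 3 values shown sit). The change methoxy in place of chloro on an aromatic carbon gives a step that the two limits leave unreadable from compound 1 to compound 2. The two cores differ by methyl in place of hydrogen on a saturated chain carbon, five bonds along the chain from an aromatic nitrogen, with a step that the two limits leave unreadable from compound 1 to compound 3. Compound 4 `CCCCCC(CCO)n1cnc2c(OC)ncnc21` is not yet measured in this assay; it arises from compound 3 by methoxy in place of chloro on an aromatic carbon, the same change as that from compound 1 to compound 2, made on the other core. Since the earlier step is unreadable because both of its values sit at the limit (the limit of > 50000 nM in this assay, at which 3 of the 3 values shown sit), the step that the limit leaves unreadable from compound 3 to compound 4 is expected to be likewise unreadable. Compound 4 is estimated at 60000 nM, most likely again reported only as a limit.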

Compound 4, half-maximal inhibitory concentration: > 50000 nM
Compound 4: only a limit was reported (the forecaster's own chance of this, stated with the estimate: 90%); the middle value lies beyond the limit too.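

No step can be read from compound 3 to compound 4 or from compound 2 to compound 4 in this assay, because all four values are limits, not numbers: the limit of > 50000 nM in this assay, at which 4 of the 4 values shown sit.

The compounds shown leave open whether any change to the shared core would give a readable value.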